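The source may hold more compounds than are shown below. What is called first, only, known or untested is meant among the compounds shown, and "the series" means these compounds.

Measured compounds:
compound 1 `CCCC/N=C(\S)OC[C@H]1OC(n2cnc3c(NC4CCOC4)ncnc32)[C@H](O)[C@@H]1O` 157 nM
compound 2 `O=C(NC1CC1)OC[C@H]1OC(n2cnc3c(NC4CCOC4)ncnc32)[C@H](O)[C@@H]1O` 209 nM
compound 3 `O=C(NC1CCC1)OC[C@H]1OC(n2cnc3c(NC4CCOC4)ncnc32)[C@H](O)[C@@H]1O` 306 nM

In an assay on DDT1 cells (Cricetulus griseus) for binding affinity to adenosine receptor A1 (Homo sapiens), read by radioligand binding (a higher number here means a weaker inhibitor, a lower number a stronger inhibitor), compound 3 gives the highest of the three numbers, yet its gaps to the other two are small: a 1.5-fold higher number from compound 2 to compound 3 (0.17 log units; within the scatter) and a 1.9-fold higher number from compound 1 to compound 3 (0.29 log units; within the scatter) both sit within the scatter, so no order among compounds 1, 2 and 3 can be claimed. The change a 1.3-fold higher number from compound 1 to compound 2 (0.12 log units; within the scatter) is likewise within the scatter.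

Compound 4 `O[C@@H]1[C@@H](CO/C(S)=N/C2CCCC2)OC(n2cnc3c(NC4CCOC4)ncnc32)[C@@H]1O` is not yet measured. It differs from compound 3 by a group of 8 heavy atoms (6 carbon, 1 nitrogen, 1 sulfur; one five-membered non-aromatic ring of carbon only) in place of a group of 7 heavy atoms (5 carbon, 1 nitrogen, 1 oxygen; one four-membered non-aromatic ring of carbon only), on an oxygen on a saturated carbon. Going by the values given here, two measured steps bear on this. The step from compound 1 to compound 3 swapped a sulfur-bearing open-chain group for a carbamate with a four-membered ring and moved the number only within the scatter; compound 4 runs that exchange in reverse, with a five-membered ring in place of the chain. The step from compound 2 to compound 3 enlarged the ring by one carbon and also stayed within the scatter. Neither step points to a change beyond the scatter, so the expected step of a 1.8-fold lower number from compound 3 to compound 4 (0.26 log units; within the scatter) is small, if anything a slightly lower number, back toward compound 1. Compound 4 is therefore estimated at 170 nM in this assay, with a range from 70 nM to 420 nM.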

Compound 4, inhibition constant: 72 nM
Estimate against measurement, compound 4: 2.4-fold (0.37 log units) above; low and high end bracket the measured number.
By their numbers in this assay, from the lowest: compound 4; then compounds 1, 2 and 3 (each within the scatter of the next).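

Going by these compounds alone, at this position, on an oxygen on a saturated carbon, compound 4 brings the first steps that lie beyond the scatter in this assay: a 4.3-fold lower number from compound 3 to compound 4 (0.63 log units; beyond the scatter) and a 2.9-fold lower number from compound 2 to compound 4 (0.46 log units; beyond the scatter), both modest and both changing the ring and the sulfur-bearing link together. The one-place reading is a 2.2-fold lower number from compound 1 to compound 4 (0.34 log units; beyond the scatter), where cyclopentyl replaces butyl on a double-bonded nitrogen with the rest of the group kept, so the substituent on that nitrogen can alone move the number beyond the scatter, whereas the ring change in a 1.5-fold higher number from compound 2 to compound 3 (0.17 log units; within the scatter) did not. Compound 4 now holds the lowest number of the four, though nothing available gives a reason for these steps.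

Open, as far as these compounds go, is whether a cyclopentyl carbamate would read like compound 4, so the shares of the ring and of the sulfur-bearing link in the steps from the carbamates cannot yet be separated. Also open, from the compounds shown here alone, is how a cyclohexyl or benzyl group on that nitrogen would read, and whether a chain ending in an amine or a carboxylic acid would hold the number.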